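Compound 4: furan-2-yl in place of methylsulfanyl

The source may hold more compounds than are shown below. What is called first, only, known or untested is meant among the compounds shown, and "the series" means these compounds.

For the measured compounds named here, the three measured members share one core. Compound 1 `CSc1cccc(NC(=O)C2CCCN(C(=O)c3cc(C(F)(F)F)cc(C(F)(F)F)c3)C2)c1`, compound 2 `CS(=O)(=O)Nc1cccc(C(=O)N2CCCC(C(=O)Nc3ccc(Cl)cc3)C2)c1` and compound 3 `CSc1cccc(C(=O)N2CCCC(C(=O)Nc3ccc(Cl)cc3)C2)c1` were all run in an ADME assay on PC-3 cells (Homo sapiens) for cytotoxicity, read by WST assay, tested at 100 uM; a lower number here means less inhibition, a higher number more inhibition at the concentration tested (going by the name of the read-out). In this assay compound 1 gives 0%, compound 2 gives 3% and compound 3 gives 0%. Going by the values given here, the only single-point step among them, a number 3 percentage points lower from compound 2 to compound 3 (within the scatter), stays within the scatter. Compound 3 therefore stands at the same figure as compound 1 at the digits shown, and its number lies within the scatter of that of compound 2.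

Compound 4 `O=C(Nc1ccc(Cl)cc1)C1CCCN(C(=O)c2cccc(-c3ccco3)c2)C1` has not yet been measured. It differs from compound 3 by furan-2-yl in place of methylsulfanyl on an aromatic carbon. Among the compounds with values here, the step from compound 2 to compound 3, a change at the same aromatic carbon, is the one measured step that bears on this, and it was within the scatter; no other measured pair touches that position. No step beyond the scatter is therefore expected in this assay, and the estimated step of no change at the digits printed from compound 3 to compound 4 (within the scatter) is nil. Compound 4 is expected to give 0%, within 0% to 12%.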

Compound 4, a percentage reported as inhibition, at one concentration (the size of the read-out at that concentration, not a potency): 0%
For compound 4 middle estimate and measured number coincide at the digits printed; low and high end bracket the measured number.
By their numbers in this assay, from the lowest: compounds 1, 3, 4 and 2 (each within the scatter of the next).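

The aromatic carbon that carried methylsulfanyl now also carries a ring. With furan-2-yl there, this assay gives no change at the digits printed from compound 3 to compound 4 (within the scatter), and the comparison with methanesulfonamido gives a number 3 percentage points lower from compound 2 to compound 4 (within the scatter), so an open group and a five-membered aromatic ring, with 5 heavy atoms in place of 2, read alike at this position while the rest of the molecule stays fixed. Nothing measured here explains this flat reading.

Since these readings all sit close to the bottom of the scale, they cannot show how far this position can shift the number at all. On these data alone, whether an amine, a carboxylic acid or a longer chain on this aromatic carbon would produce a step beyond the scatter remains open.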